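The source may hold more compounds than are shown below. What is called first, only, known or untested is meant among the compounds shown, and "the series" means these compounds.

Measured in an ADME assay on the whole organism (Rattus norvegicus, strain Sprague-Dawley) for pharmacokinetics, read by LC-MS, with a stated time of 30 min; on this read-out lower numbers stand for narrower distribution and higher numbers for wider distribution into tissues:
- compound 1 `N#Cc1ccc(O[C@H]2CN(S(=O)(=O)c3ccc(Cl)cc3Cl)C[C@@]2(O)CO)cc1F`: 3.2 L/kg
- compound 2 `N#Cc1ccc(O[C@H]2CN(S(=O)(=O)c3ccc(C(F)(F)F)cc3)C[C@@]2(O)CO)cc1F`: 5.9 L/kg

Within the data shown here, only two numbers are available, and compound 1 sits within the scatter of compound 2, its only neighbour: a 1.8-fold higher number from compound 1 to compound 2 (0.27 log units; within the scatter). That step is 4-(trifluoromethyl)phenyl in place of 2,4-dichlorophenyl on a sulfonyl sulfur.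

Compound 3 `N#Cc1ccc(O[C@H]2CN(S(=O)(=O)c3ccc(Cl)cc3Cl)C[C@@]2(O)CN)cc1F` keeps the rest of compound 1 and changes one group: amino in place of hydroxy on a saturated chain carbon bound to a saturated ring carbon. In words, this is amino in place of hydroxy on a saturated chain carbon bound to a saturated ring carbon, or hydroxymethyl to aminomethyl.

Among the measured compounds shown here, no measured step covers this place. The step to compound 2 lies elsewhere in the structure and serves only as a rough gauge of size, so direction rests on judgement alone. In this assay, a modest move to a higher number is expected, and a result within the scatter would be unsurprising. The expected change is a 1.7-fold higher number from compound 1 to compound 3 (0.24 log units; within the scatter).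

For compound 3 the estimate is 5.5 L/kg, with an expected range from 2.5 L/kg to 12 L/kg.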

Compound 3, volume of distribution at steady state: 7.7 L/kg
Estimate against measurement, compound 3: 1.4-fold (0.15 log units) below, within the range that was stated.
By their numbers in this assay, from the lowest: compounds 1, 2 and 3 (each within the scatter of the next, the first and the last beyond it).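

In this assay, among these compounds, amino in place of hydroxy on a saturated chain carbon bound to a saturated ring carbon gives a 2.4-fold higher number from compound 1 to compound 3 (0.38 log units; beyond the scatter), the only step so far that lies beyond the scatter and the first reading at this position. The hydroxymethyl to aminomethyl change exchanges one heavy atom, oxygen for nitrogen, with the counted hydrogen-bond donors and acceptors the same on both sides, yet it registers on this read-out, whereas the change on the sulfonyl sulfur, a 1.8-fold higher number from compound 1 to compound 2 (0.27 log units; within the scatter), stays within the scatter. Nothing measured in the series accounts for this step, so its origin remains unassigned.

From the compounds shown here alone, the finding rests on a single pair with 2,4-dichlorophenyl on the sulfonyl sulfur, so it remains open whether aminomethyl gives a similar step alongside 4-(trifluoromethyl)phenyl. Also open, going by these compounds, is how this position responds to a dimethylamine, a carboxylic acid or a longer aminoethyl chain, which would show whether the step is specific to aminomethyl or extends to other groups at this place.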